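The compounds below may be only part of what the source reports. "The series", "measured", "known", "first", "only" and "open" are said of these compounds alone.

Measured so far in a functional assay on HCT-116 cells (Homo sapiens) for cytotoxicity, read by sulforhodamine B assay, with a stated time of 72 h; on this read-out lower numbers stand for stronger inhibition and higher numbers for weaker inhibition:
compound 1, `C=C1C(=O)O[C@@H]2CC(C)=C([C@@H](C)CCCOC(C)=O)[C@@H](OC(=O)CCl)[C@H]12`, gives 18800 nM;
compound 2, `C=C1C(=O)O[C@@H]2CC(C)=C([C@@H](C)CCCOC(C)=O)[C@@H](OC(=O)CN3CCCCC3)[C@H]12`, gives 13900 nM.

For the measured compounds named here, compound 2 has the lowest of the two numbers in this assay, but its only neighbour, compound 1, lies close: the step of a 1.4-fold lower number from compound 1 to compound 2 (0.13 log units; within the scatter), so the two values cannot be told apart.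

Compound 3, `C=C1C(=O)O[C@@H]2CC(C)=C([C@@H](C)CCCOC(C)=O)[C@@H](OC(=O)COc3cccc4cccnc34)[C@H]12`, has not yet been measured. It differs from compound 2 by (quinolin-8-yl)oxy in place of piperidin-1-yl on a saturated chain carbon bound to a carbonyl carbon.

Going by the values given here, only one measured step exists, the one from compound 1 to compound 2, and it exchanged the group at the same place: a saturated chain carbon bound to a carbonyl carbon. That exchange left the number within the scatter. The present change brings in a larger and quite different group, (quinolin-8-yl)oxy in place of piperidin-1-yl, so the measured step is only a weak guide. With nothing to indicate a large move in either direction, the expectation for compound 3 is a step of about a 1.2-fold lower number from compound 2 to compound 3 (0.06 log units; within the scatter), that is, no change beyond the scatter.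

Compound 3 is therefore estimated at 12000 nM, with a likely range from 4000 nM to 36000 nM.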

Compound 3, half-maximal inhibitory concentration: 12100 nM
Beside the measured number, compound 3's estimate is 1.0-fold (0.00 log units) below it; measured number inside the range.
By their numbers in this assay, from the lowest: compounds 3, 2 and 1 (each within the scatter of the next).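

In this assay, the place on a saturated chain carbon bound to a carbonyl carbon has now carried three quite different groups, and the numbers still do not separate. Putting (quinolin-8-yl)oxy in place of piperidin-1-yl gives a 1.1-fold lower number from compound 2 to compound 3 (0.06 log units; within the scatter), and putting it in place of chloro gives a 1.6-fold lower number from compound 1 to compound 3 (0.19 log units; within the scatter). So a group with two six-membered aromatic rings and 11 heavy atoms reads the same, within the scatter, as piperidin-1-yl with 6 heavy atoms or as a single chloro, and among these three compounds the size and kind of group at this place make no visible difference. Nothing measured here offers an explanation for this flat result.

Whether any group at this place can move the number beyond the scatter stays open, since the compounds shown include neither a carboxylic acid nor an open-chain amine such as dimethylamino. Also open, on these data alone, is whether a plain phenoxy group, without the ring nitrogen of (quinolin-8-yl)oxy, would read the same as compound 3 in this assay.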